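Removing the aromatic methyl from compound 3

A few compounds are considered here, and "the series" means these few. Any claim that something is new, unique, unknown or untested is made for them only; others in the source may bear on it.

In a functional assay on MCF7 cells (Homo sapiens) for antiproliferative activity, read by MTT assay (a lower number here means a stronger inhibitor, a higher number a weaker inhibitor), compound 1 `CC/C=C\C/C=C\C/C=C\CCCCCCCc1cc(=O)c2c(O)cc(OCOC)cc2o1` gives 17500 nM and compound 2 `CCCCC/C=C\C/C=C\CCCCCCCc1cc(=O)c2c(O)cc(O)c(C)c2o1` gives 17500 nM. Compound 3 `CCCCC/C=C\C/C=C\CCCCCCCc1cc(=O)c2c(O)cc(OCOC)c(C)c2o1` reads > 84100 nM, which is a limit and not a number. This is the limit of > 84100 nM in this assay, at which 1 of the 3 values shown sits.

Compound 4 `CCCCC/C=C\C/C=C\CCCCCCCc1cc(=O)c2c(O)cc(OCOC)cc2o1` departs from compound 3 by one change: hydrogen in place of methyl on an aromatic carbon, ortho to a methoxymethoxy group and para to a hydroxy group (hydrogen in place of methyl on an aromatic carbon). For the measured compounds named here, the one measured step, an at least 4.8-fold higher number from compound 2 to compound 3 (0.68 log units; beyond the scatter), puts methoxymethyl in place of hydrogen on an oxygen with the methyl kept, so it does not test the methyl itself. Compound 4 shares the methoxymethoxy group and the hydrogen with compound 1, which differs only in the chain and gives 17500 nM. That value is the closest guide. From the compounds shown here alone, the expected change is an at least 3.3-fold lower number from compound 3 to compound 4 (0.52 log units; beyond the scatter), toward a lower number in this assay and beyond the scatter, though its exact size stays open with only a limit at its start. For compound 4 the estimated value is 25000 nM, with an expected range of 10000 nM to 70000 nM.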

Compound 4, half-maximal inhibitory concentration: > 67200 nM
Compound 4 gave a limit, no number; the forecaster's own chance of this, stated with the estimate: 20%; at least 2.6-fold (0.42 log units) between middle value and limit.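

Compound 3 and compound 4 both stand as limits, so the step between them cannot be read. In this assay, compound 4 gives a limit and not a number, so hydrogen in place of methyl on this aromatic carbon, ortho to a methoxymethoxy group and para to a hydroxy group, does not yield a readable value: the limit of > 67200 nM in this assay, at which 1 of the 4 values shown sits.

For the compounds shown here, the one readable new step concerns the chain and not this position: butyl in place of but-1-en-1-yl gives an at least 3.8-fold higher number from compound 1 to compound 4 (0.58 log units; beyond the scatter).

From the compounds shown here alone, the size of any effect of the methyl at this carbon stays open, with the methoxymethoxy group present or with a free hydroxy group in its place. Also open, going by these compounds, is whether an ethyl group or an amine at this carbon, or a carboxylic acid at the end of the chain, would give a number in this assay.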